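Trimethoxybenzyl analogue of compound 2 in the cell growth series

The source may report more compounds than this note shows. Statements on the series, on what has been measured and on what is new or still open speak of the compounds shown alone.

Measured so far:
compound 1 `Nc1cc(N)c2nc(-c3ccccc3)c(NCc3ccc(Cl)c(Cl)c3)nc2c1` — 45700 nM
compound 2 `COc1ccc(CNc2nc3cc(N)cc(N)c3nc2-c2ccccc2)cc1OC` — 66100 nM

Notes. In a functional assay on NCI/ADR-RES cells (Homo sapiens) for inhibition, read by sulforhodamine B assay, with a stated time of 48 h (a higher number here means a weaker inhibitor of growth, a lower number a stronger inhibitor of growth), compound 1 gives 45700 nM and compound 2 gives 66100 nM. Among the compounds with values here, the only step between them, a 1.4-fold higher number from compound 1 to compound 2 (0.16 log units; within the scatter), stays within the scatter, so nothing about the order of compounds 1 and 2 can be read from these two numbers; compound 2 simply carries the higher of the two values, with compound 1 nearest.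

Compound 3 `COc1cc(CNc2nc3cc(N)cc(N)c3nc2-c2ccccc2)cc(OC)c1OC` is not yet measured in this assay. It differs from compound 2 by methoxy in place of hydrogen on an aromatic carbon. Within the data shown here, the one measured step bears on it only loosely: exchanging the substituents of the aromatic ring on the saturated chain carbon changed the number by a 1.4-fold higher number from compound 1 to compound 2 (0.16 log units; within the scatter), within the scatter. A further change to this ring is therefore expected to leave the number about where compound 2 stands, with no step beyond the scatter, that is a 1.1-fold higher number from compound 2 to compound 3 (0.02 log units; within the scatter). For compound 3 the estimate is 70000 nM, within 30000 nM to 160000 nM.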

Compound 3, concentration for total growth inhibition: 21900 nM
The estimate for compound 3 lay 3.2-fold (0.50 log units) above the measured number, and the stated range ends above it.
By their numbers in this assay, from the lowest: compound 3; then compounds 1 and 2 (each within the scatter of the next).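

In this assay, within the data shown here, methoxy in place of hydrogen on this aromatic carbon gives a 3.0-fold lower number from compound 2 to compound 3 (0.48 log units; beyond the scatter), a modest change but the first step to lie beyond the scatter. The exchange between compound 1 and compound 2 stayed within the scatter, so only now does the ring on the saturated chain carbon show a response to substitution, here at the place ortho to a methoxy group and meta to a large group. No measurement at hand offers an explanation for this step.

As far as these compounds go, whether a hydroxyl, an amine or a longer ethoxy chain at this carbon would move the number in the same way remains open. Also open, from the compounds shown here alone, is whether the step carries over to a ring bearing chlorine, as in compound 1.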